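A few compounds are considered here, and "the series" means these few. Any claim that something is new, unique, unknown or untested is made for them only; others in the source may bear on it.

Measured compounds:
compound 1 `O=C(/C(=C\c1ccc(O)cc1O)Sc1ccc(Br)cc1)c1ccc(Cl)cc1` gives 50000 nM
compound 2 `COc1ccc(/C=C(/SCc2ccc(Cl)cc2)C(=O)c2ccc(Cl)cc2)cc1` gives 10000 nM
compound 3 `CSc1ccc(/C=C(/SCc2ccc(Cl)cc2)C(=O)c2ccc(Cl)cc2)cc1` gives 25000 nM

These were measured in a functional assay on DU-145 cells (Homo sapiens) for inhibition, read by trypan blue exclusion, with a stated time of 96 h; a higher number here means a weaker inhibitor of growth, a lower number a stronger inhibitor of growth. Compound 3 gives the second highest of the three numbers: compound 1 lies a step above it that falls within the scatter, while compound 2 lies a step below it that is beyond the scatter, a 2.5-fold higher number from compound 2 to compound 3 (0.40 log units; beyond the scatter). Compound 4 `O=C(/C(=C\c1ccc(O)cc1O)SCc1ccc(Cl)cc1)c1ccc(Cl)cc1` has not yet been measured. It differs from compound 3 in one place: 2,4-dihydroxyphenyl in place of 4-(methylsulfanyl)phenyl on a double-bonded chain carbon bound to a double-bonded chain carbon. Going by the values given here, no measured step makes exactly this exchange, so the only guide is compound 1, which carries the same 2,4-dihydroxyphenyl group on a different sulfur substituent and gives 50000 nM in this assay, a number close to that of compound 3. The expected step of a 1.6-fold higher number from compound 3 to compound 4 (0.20 log units; within the scatter) is therefore a small rise in the number, likely within the scatter. For compound 4 the estimate in this assay is 40000 nM, with a range from 15000 nM to 100000 nM.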

Compound 4, concentration for 50% growth inhibition: 50000 nM
The estimate for compound 4 lay 1.3-fold (0.10 log units) below the measured number, and the stated range covers the measured number.
By their numbers in this assay, from the lowest: compound 2; then compounds 3, 1 and 4 (each within the scatter of the next).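

In this assay putting 2,4-dihydroxyphenyl in place of 4-methoxyphenyl on a double-bonded chain carbon bound to a double-bonded chain carbon gives a 5.0-fold higher number from compound 2 to compound 4 (0.70 log units; beyond the scatter) and so shows a real loss of growth inhibition at this position. Going by these compounds alone, the same group in place of 4-(methylsulfanyl)phenyl gives a 2.0-fold higher number from compound 3 to compound 4 (0.30 log units; within the scatter) and cannot be told apart from no change, so only the step from the 4-methoxyphenyl compound stands out of the scatter. On the sulfur, 4-chlorobenzyl in place of 4-bromophenyl gives no change at the digits printed from compound 1 to compound 4 (within the scatter) with 2,4-dihydroxyphenyl in place, so that exchange leaves the number as it was.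

No supporting measurement bears on these steps. Still open, as far as these compounds go, is how a ring carrying an amine or a carboxylic acid would behave at this position, and whether a longer chain on the sulfur would matter.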